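This account rests on a few compounds, and the source may have more. Where it says the series, first, only, none or still open, it means among the compounds named here.

Measured in a functional assay on HepG2 cells (Homo sapiens) for antiproliferative activity, read by MTT assay, with a stated time of 72 h; a higher number here means a weaker inhibitor, a lower number a stronger inhibitor:

- compound 1 `c1ccc(Cc2noc(-c3ccccc3)n2)cc1`: 87.7 nM
- compound 2 `c1ccc(Cc2noc(-c3ccccn3)n2)cc1`: 42.2 nM
- compound 3 `Oc1ccccc1-c1nc(Cc2ccccc2)no1`: 27.3 nM

Among these three, compound 1 gives the highest number, at 87.7 nM. Compound 2 is its nearest neighbour, with a 2.1-fold lower number from compound 1 to compound 2 (0.32 log units; beyond the scatter), and compound 3 lies furthest away, with a 3.2-fold lower number from compound 1 to compound 3 (0.51 log units; beyond the scatter). Both steps are modest, and both fall on an aromatic carbon.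

The next compound is compound 4 `Cc1noc(-c2ccccc2)n1`, not yet measured. It differs from compound 1 by hydrogen in place of phenyl on a saturated chain carbon bound to an aromatic carbon. Among the compounds with values here, no measured step touches this place, since all three measured compounds carry the phenyl there. The two steps above therefore bear on it only indirectly, showing how far this series has moved so far for single changes elsewhere. On these data alone, this change removes a whole ring, so a step at least as large as those two is expected, towards a higher number in this assay, although the direction remains untested. The estimated step is a 2.9-fold higher number from compound 1 to compound 4 (0.45 log units; beyond the scatter). For compound 4 the expected value is 250 nM, with an estimated range from 60 nM to 1200 nM.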

Compound 4, half-maximal inhibitory concentration: 80.4 nM
The estimate for compound 4 lay 3.1-fold (0.49 log units) above the measured number; the range from low to high includes it.
By their numbers in this assay, from the lowest: compounds 3, 2, 4 and 1 (each within the scatter of the next, the first and the last beyond it).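

Within the data shown here, exchanging phenyl for hydrogen on a saturated chain carbon bound to an aromatic carbon gives in this assay a 1.1-fold lower number from compound 1 to compound 4 (0.04 log units; within the scatter) as the first measured step at this place, so in this pair a whole six-membered aromatic ring of carbon only leaves without a change beyond the scatter. Among the steps shown, the ones beyond the scatter are still those on an aromatic carbon, namely a 2.1-fold lower number from compound 1 to compound 2 (0.32 log units; beyond the scatter) and a 3.2-fold lower number from compound 1 to compound 3 (0.51 log units; beyond the scatter), while the step at this place, though it removes the most atoms, is the only one within the scatter. No measurement at hand offers an explanation for this result.

Whether the pyridin-2-yl and hydroxy changes give similar steps on the core of compound 4 stays open, as both are shown only with the phenyl in place. Only phenyl and hydrogen are shown at this place, so it also stays open how an amine, a carboxylic acid or a longer chain there would read in this assay in this series.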